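The source may hold more compounds than are shown below. What is called first, only, known or untested is meant among the compounds shown, and "the series" means these compounds.

Measured compounds:

Compound 1 `COc1cc2c(Oc3ccc(NC(=O)NN4C(=O)CSC4c4c(F)cccc4F)c4ccccc34)ccnc2cc1OCCCN1CCCC1` gives 2360 nM
Compound 2 `COc1cc2c(Oc3c(F)cc(NC(=O)NN4C(=O)CSC4c4c(F)cccc4F)cc3F)ccnc2cc1OCCCN1CCCC1` gives 560 nM
Compound 3 `COc1cc2c(Oc3c(F)cc(NC(=O)NN4C(=O)CCSC4c4c(F)cccc4F)cc3F)ccnc2cc1OCCCN1CCCC1` gives 400 nM

These three compounds were tested in a functional assay on A549 cells (Homo sapiens) for antiproliferative activity, read by MTT assay, with a stated time of 72 h; on this read-out lower numbers stand for stronger inhibition and higher numbers for weaker inhibition. Compound 3 carries the lowest of the three numbers. The nearest value is that of compound 2, and the two lie within the scatter of each other, so no order between them can be read. Compound 1 stands furthest away, with a number that lies beyond the scatter from compound 3.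

Compound 4 `COc1cc2c(Oc3c(F)cc(NC(=O)NN4C(=O)CCSC4c4c(F)cccc4F)cc3F)ccnc2cc1OCCCN1CCc2sccc2C1` has not yet been measured in this assay. It differs from compound 3 in one place: a group of 9 heavy atoms (7 carbon, 1 nitrogen, 1 sulfur; one five-membered aromatic ring with 1 hetero atom, one six-membered non-aromatic ring with 1 hetero atom) in place of a group of 5 heavy atoms (4 carbon, 1 nitrogen; one five-membered non-aromatic ring with 1 hetero atom), on a saturated chain carbon, three bonds along the chain from an oxygen on an aromatic ring. Among the compounds with values here, the change sits on the solubilising chain of the shared core, far from the urea and the ring bearing the two fluorine atoms, and no pair among the measured compounds shows what a change at this position does. The step from compound 3 to compound 4 in this assay is therefore expected to be small, in either direction, and most likely to fall within the scatter, which is what a 1.3-fold higher number from compound 3 to compound 4 (0.10 log units; within the scatter) expresses. Compound 4 is accordingly estimated at 500 nM in this assay, with a range from 150 nM to 1600 nM.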

Compound 4, half-maximal inhibitory concentration: > 20000 nM
Compound 4 ended at the assay's limit; the forecaster's own chance of this, stated with the estimate: 3%; middle value at least 40-fold (1.60 log units) from the limit.
By their numbers in this assay, from the lowest: compounds 3 and 2 (each within the scatter of the next); then compound 1. At a limit, above all of these: compound 4.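

In this assay, putting the group of 9 heavy atoms, with its five-membered aromatic ring and six-membered non-aromatic ring, in place of pyrrolidin-1-yl on a saturated chain carbon, three bonds along the chain from an oxygen on an aromatic ring, gives an at least 50-fold higher number from compound 3 to compound 4 (1.69 log units; beyond the scatter). Within the data shown here, this is the first step at this position, and it shows that the read-out is far from indifferent to the ring group carried at the end of the chain, even though the rest of the molecule is unchanged. Compound 4 gives > 20000 nM, which is a limit of the assay and not a number, so the step marks a lower bound on the change rather than its full size, and compound 4 alone stands at that limit: the limit of > 20000 nM in this assay, at which 1 of the 4 values shown sits.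

The single step replaces the whole group, so the compounds shown do not tell whether the five-membered aromatic ring or the six-membered non-aromatic ring goes with the loss, a question that a piperidine or a morpholine on the same chain would address. On these data alone, it also remains open whether the same change would have a similar effect on the five-membered ring of compound 2, or with a longer chain.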